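Chloro for methylsulfanyl on the core of compound 1

This account rests on a few compounds, and the source may have more. Where it says the series, first, only, none or still open, it means among the compounds named here.

Measured compounds:
compound 1 `CSc1nc(N)c2ncn(C3C(O)C(O)[C@@]4(COP(=O)(O)OP(=O)(O)OP(=O)(O)O)C[C@@H]34)c2n1`: 23 nM
compound 2 `CSc1nc(N)c2ncn([C@H]3[C@H](O)[C@H](O)[C@@]4(COP(=O)(O)OP(=O)(O)O)C[C@@H]34)c2n1`: 0.4 nM

In an assay on cells with P2Y purinoceptor 1 (Homo sapiens) as the target, read by inositol phosphate accumulation (on this read-out lower numbers stand for an effect already at smaller amounts and higher numbers for an effect only at larger amounts of compound), compound 1 gives 23 nM, and in this assay compound 2 gives 0.4 nM. Compound 1 thus stands at the highest of the two numbers; the gap down to compound 2 lies beyond the scatter, but the two compounds differ in more than one place, so no single step can be read from that gap.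

Compound 3 `Nc1nc(Cl)nc2c1ncn2C1C(O)C(O)[C@@]2(COP(=O)(O)OP(=O)(O)OP(=O)(O)O)C[C@@H]12` has not been measured. It differs from compound 1 by chloro in place of methylsulfanyl on an aromatic carbon of the six-membered aromatic ring with two nitrogen atoms, between two ring nitrogen atoms, meta to the amino group, meta and para to a fused ring. Among the measured compounds shown here, no measured pair shows this change, so its size is not known from the series. The expectation is a modest loss for compound 3, a 2.6-fold higher number from compound 1 to compound 3 (0.42 log units; beyond the scatter), a step that may or may not clear the scatter. The estimated value of compound 3 in this assay is 60 nM, with a range from 15 nM to 250 nM.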

Compound 3, half-maximal effective concentration: 7 nM
Compound 3: middle estimate off by 8.6-fold (0.93 log units), on the high side, and the stated range ends above it.
By their numbers in this assay, from the lowest: compound 2; then compound 3; then compound 1.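

In this assay, among the compounds shown here, chloro in place of methylsulfanyl on the aromatic carbon between two ring nitrogen atoms gives a 3.3-fold lower number from compound 1 to compound 3 (0.52 log units; beyond the scatter), the first step that can be read at a single place. On the core of compound 1, methylsulfanyl is therefore not required at this carbon for an effect at low amounts: chloro, with one heavy atom against two and no hydrogen-bond acceptor counted, moves the number down beyond the scatter. No measurement at hand gives a reason for this step.

The compounds shown leave open whether another group at this carbon, such as an amine, a methoxy group or a longer chain like ethylsulfanyl, would move the number in the same direction, and so whether the step follows the size of the group or is particular to chloro. They also leave open whether the same change would give a step of similar size on compound 2, which stands at 0.4 nM and differs from compound 1 in more than one place.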